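Swapping the Hexyloxy Chain for a Benzyloxy Group

This account rests on a few compounds, and the source may have more. Where it says the series, first, only, none or still open, it means among the compounds named here.

Compound 1 `CCCCCCOc1cccc(O)c1C(=O)/C=C/c1ccc(O)cc1` carries a hexyloxy chain on its core. In a functional assay on ACHN cells (Homo sapiens) for antiproliferative activity, read by sulforhodamine B assay (a higher number here means a weaker inhibitor of growth, a lower number a stronger inhibitor of growth), compound 1 gives > 30000 nM, which is a limit of the assay rather than a number. Compound 2 `O=C(/C=C/c1ccc(O)cc1)c1c(O)cccc1OCC1CCCCC1` also stops at the limit, giving > 30000 nM in this assay. Compound 3 `O=C(/C=C/c1ccc(O)cc1)c1c(O)cccc1OCCC1CCCC1` does give a number, 3400 nM in this assay. Compound 1 therefore stands at the limit, a position it shares with one other compound (the limit of > 30000 nM in this assay, at which 2 of the 3 values shown sit), so nothing finer can be said of it.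

Compound 4 `O=C(/C=C/c1ccc(O)cc1)c1c(O)cccc1OCc1ccccc1` differs from compound 1 by phenyl in place of pentyl on a saturated chain carbon bound to an oxygen on an aromatic ring. Among the measured compounds shown here, three measured steps bear on this. The step that the two limits leave unreadable from compound 1 to compound 2 cannot be read, since both ends are limits. The step of an at least 8.8-fold lower number from compound 1 to compound 3 (0.94 log units; beyond the scatter) and the step of an at least 8.8-fold lower number from compound 2 to compound 3 (0.94 log units; beyond the scatter) both show that a cyclopentylmethyl group on the saturated chain carbon bound to the oxygen on the aromatic ring clears the limit. Compound 4 carries a benzyl group at that same place, which resembles compound 3 more than compound 2. A drop beyond the scatter, though smaller than the at least modest steps to compound 3, is expected.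

Compound 4 is expected to give about 9000 nM, between 2500 nM and 30000 nM. The estimated step is an at least 3.3-fold lower number from compound 1 to compound 4 (0.52 log units; beyond the scatter).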

Compound 4, concentration for 50% growth inhibition: > 30000 nM
Compound 4: no number, only a limit; the forecaster's own chance of this, stated with the estimate: 35%; middle value at least 3.3-fold (0.52 log units) away from the limit.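

Among the compounds shown here, the one step that can be read is an at least 8.8-fold higher number from compound 3 to compound 4 (0.94 log units; beyond the scatter), so at this place on the shared core, phenyl does not keep the measurable growth inhibition that cyclopentylmethyl gives in this assay. The steps among compound 1, compound 2 and compound 4 cannot be read, since both ends of each are limits, and these three compounds therefore cannot be ranked against one another. Among the four compounds, only compound 3 gives a number, which makes it the exception, while the hexyloxy, cyclohexylmethyl and benzyloxy compounds all stop at the same limit of the assay: the limit of > 30000 nM in this assay, at which 3 of the 4 values shown sit.

For the compounds shown here, it remains open whether a phenethyl group in place of the benzyl group, which would make the chain on the oxygen as long as the one in compound 3, would bring the aromatic ring into the measurable range. As far as these compounds go, it is also open whether an amine or a carboxylic acid on the phenyl ring of compound 4 would give a number, or whether the value would stay at the limit.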